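A few compounds are considered here, and "the series" means these few. Any claim that something is new, unique, unknown or untested is made for them only; others in the source may bear on it.

Measured so far:
compound 1, `CCNC(=O)Nc1ccc(/C=C\c2cccc(Cl)c2)cc1`, gives 32000 nM 
compound 2, `CCNC(=O)Nc1ccc(/C=C\c2cc(OC)c(OC)c(OC)c2)cc1`, gives 21000 nM 
compound 3, `COc1cc(/C=C\c2ccc(N3CCNC3=O)cc2)cc(OC)c1OC`, gives 2.6 nM 

All three were tested in a functional assay on MCF7 cells (Homo sapiens) for inhibition, read by sulforhodamine B assay, with a stated time of 48 h; on this read-out lower numbers stand for stronger inhibition and higher numbers for weaker inhibition. Compound 1 and compound 2 have different cores, and the difference between the two cores is not broken down here; their values lie within the usual scatter of each other, so no order between them can be read. Compound 3 differs from compound 2 in one place, (2-oxoimidazolidin-1-yl in place of (ethylcarbamoyl)amino on an aromatic carbon), and that single change brought an 8100-fold lower number from compound 2 to compound 3 (3.91 log units; beyond the scatter).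

Compound 4, `O=C1NCCN1c1ccc(/C=C\c2cccc(Cl)c2)cc1`, has not yet been measured in this assay. It stands to compound 1 as compound 3 stands to compound 2: 2-oxoimidazolidin-1-yl in place of (ethylcarbamoyl)amino on an aromatic carbon. This is the same kind of change, not the same one, as the surroundings differ: in compound 2 the group sits para to a large group, in compound 1 para to a group of 9 heavy atoms. The earlier step rests on one pair with a different core, so for compound 4 a smaller, though still large, step is expected, a 320-fold lower number from compound 1 to compound 4 (2.51 log units; beyond the scatter). Compound 4 is expected to give about 100 nM in this assay, estimated between 5 nM and 2000 nM.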

Compound 4, half-maximal inhibitory concentration: 38 nM
The estimate for compound 4 lay 2.6-fold (0.42 log units) above the measured number; low and high end bracket the measured number.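

On the core of compound 1, too, putting 2-oxoimidazolidin-1-yl in place of (ethylcarbamoyl)amino strongly lowered the number in this assay, with an 840-fold lower number from compound 1 to compound 4 (2.93 log units; beyond the scatter). The direction of the change therefore carried over from one core to the other, but its size did not: the same change on two cores in this assay, an 8100-fold lower number (3.91 log units; beyond the scatter) from compound 2 to compound 3 and an 840-fold lower number (2.93 log units; beyond the scatter) from compound 1 to compound 4, 9.6-fold (0.98 log units) apart, beyond the scatter of two such steps. These two pairs do not explain why the size differs, and they cannot show that the change would act in the same way on any further core, since a trend cannot be drawn from two examples.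

The compounds shown leave open whether the five-membered ring itself is needed, or whether a six-membered ring of the same kind, or the same ring carrying a methyl group, would also keep the number low. They also leave open how the change behaves when the core carries other groups, such as an amine or a carboxylic acid, in place of the chlorine or the methoxy groups.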